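Difluoromethyl in place of ethyl: expected effect on potency

A few compounds are considered here, and "the series" means these few. Any claim that something is new, unique, unknown or untested is made for them only; others in the source may bear on it.

Compound 1 `Cc1ccc(Nc2nc(N)nc(COc3ccc4ccc(=O)oc4c3)n2)cc1` and compound 2 `CCc1cc(=O)oc2cc(OCc3nc(N)nc(Nc4ccc(C)cc4)n3)ccc12` share a core and differ in one place. In an assay on COS-7 cells for agonist activity at Free fatty acid receptor 1 (Homo sapiens), read by scintillation counting and inositol phosphate accumulation, with a stated time of 90 min (on this read-out lower numbers stand for an effect already at smaller amounts and higher numbers for an effect only at larger amounts of compound), compound 1 gives 1280 nM, and compound 2 gives 2640 nM. The step of a 2.1-fold higher number from compound 1 to compound 2 (0.31 log units; beyond the scatter) is the only measured step so far, and it places compound 2 at the higher of the two numbers shown, with compound 1 as the nearest.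

Compound 3 `Cc1ccc(Nc2nc(N)nc(COc3ccc4c(C(F)F)cc(=O)oc4c3)n2)cc1` is not yet measured. It is derived from compound 2 by the change (difluoromethyl in place of ethyl on an aromatic carbon). Among the compounds with values here, no measured step swaps one group for another at this carbon; the only step that bears on the position is a 2.1-fold higher number from compound 1 to compound 2 (0.31 log units; beyond the scatter), which shows that putting a group there moved the number modestly upward. Difluoromethyl occupies the same carbon as ethyl, so a number near that of compound 2 is expected, possibly anywhere between the two measured values. The expected step from compound 2 to compound 3 is therefore small, a 1.3-fold lower number from compound 2 to compound 3 (0.12 log units; within the scatter). Compound 3 is estimated at 2000 nM, within 800 nM to 5000 nM.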

Compound 3, half-maximal effective concentration: 3180 nM
For compound 3 the middle estimate is 1.6-fold (0.20 log units) below the measured one; measured number inside the range.
By their numbers in this assay, from the lowest: compound 1; then compounds 2 and 3 (each within the scatter of the next).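

In this assay, within the data shown here, this is the first exchange of one group for another on the aromatic carbon opposite the ring oxygen, and it gives a 1.2-fold higher number from compound 2 to compound 3 (0.08 log units; within the scatter); at this position, ethyl and difluoromethyl are not told apart, although the entering group has one more heavy atom and brings in two fluorine atoms. Set against hydrogen, difluoromethyl gives a 2.5-fold higher number from compound 1 to compound 3 (0.40 log units; beyond the scatter) and ethyl gives a 2.1-fold higher number from compound 1 to compound 2 (0.31 log units; beyond the scatter), so among these three compounds hydrogen on this carbon goes with the lowest number, no compound goes against that, and the upward move is no longer tied to ethyl alone. No independent measurement bears on why these two groups read alike.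

Still open, from the compounds shown here alone, is whether an amine, a hydroxyl or a carboxylic acid on this carbon would stay close to these numbers or move away from them in either direction. Also open, going by these compounds, is whether a longer chain such as butyl, or a phenyl ring, would extend the same modest upward step or depart from it.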